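Ethyl in Place of Ethoxy: Toward Compound 3

The source may report more compounds than this note shows. Statements on the series, on what has been measured and on what is new or still open speak of the compounds shown alone.

Compound 1 `CCOC(COC(N)=O)C1=C(N2CC2)C(=O)C(C)=C(N2CC2)C1=O`: 4.62
Compound 2 `CCC1=C(N2CC2)C(=O)C(CCOC(N)=O)=C(N2CC2)C1=O`: 4.88

Of the compounds shown here, two have been measured in a functional assay on L1210 cells (Mus musculus), with a stated time of 1 days; a lower number here means a less potent compound, a higher number a more potent compound, by a factor of ten per unit of this negative logarithm. Compound 1 gives 4.62, and compound 2 gives 4.88. Among the measured compounds shown here, compound 1 stands at one end of these two numbers, but compound 2 sits within the usual scatter of it, so nothing separates the pair, and no step between them can be drawn; the two structures also differ in more than one place.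

Compound 3 `CCC(COC(N)=O)C1=C(N2CC2)C(=O)C(C)=C(N2CC2)C1=O` has not yet been measured. It differs from compound 1 in a single place: ethyl in place of ethoxy on a saturated chain carbon bound to a double-bonded ring carbon and a saturated chain carbon. For the measured compounds named here, no measured step of this kind is available, so the expectation rests on the two numbers alone. Compound 2, which carries an ethyl chain on its core and gives 4.88, offers the only hint that an ethyl is tolerated in this series. The step of a number 0.13 log units higher from compound 1 to compound 3 (within the scatter) is therefore expected to be small, with no move beyond the scatter in either direction. Compound 3 is estimated at 4.75, with a range from 4.3 to 5.25.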

Compound 3, logarithm of the reciprocal of the active concentration, log(1/C): 5.2
The estimate for compound 3 lay 0.45 log units below the measured number, and the stated range covers the measured number.
By their numbers in this assay, from the lowest: compounds 1 and 2 (each within the scatter of the next); then compound 3.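

In this assay, among the compounds shown here, ethyl in place of ethoxy on a saturated chain carbon bound to a double-bonded ring carbon and a saturated chain carbon gives a number 0.58 log units higher from compound 1 to compound 3 (beyond the scatter) and is the first single change in this set whose size can be read. It shows that the number in this assay responds to the group at this place on the shared core, and that the oxygen-bearing ethoxy can be exchanged here without a loss. The exchange removes one heavy atom, the oxygen, and with it a hydrogen-bond acceptor, but nothing available shows what lies behind the step.

The compounds shown do not tell whether the step follows from the loss of the oxygen or from some other difference between the two groups; a propyl group or a methoxy group at the same place would bear on that question. They also leave open how a smaller methyl group, a hydroxy group or an amine would fare on this carbon, and so how far the gain extends beyond ethyl.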